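The compounds below may be only part of what the source reports. "The series", "measured", "known", "first", "only" and "open" are said of these compounds alone.

Measured so far in a functional assay on HepG2 cells (Homo sapiens) for cytotoxicity, read by MTT assay, with a stated time of 48 h; on this read-out higher numbers stand for weaker inhibition and lower numbers for stronger inhibition: compound 1 `CC(=O)Nc1ccc2nc(SCC(=O)NCc3ccccc3)sc2c1` gives 9200 nM. Compound 2 `CNC(=O)CSc1nc2ccc(NC(=O)c3ccc([N+](=O)[O-])cc3)cc2s1` reaches only a limit of the assay, > 100000 nM. Compound 3 `O=C(CSc1nc2ccc(NC(=O)c3ccc([N+](=O)[O-])cc3)cc2s1)NCc1ccccc1` likewise reaches only a limit, > 100000 nM.

From compound 3 to compound 1 the change is methyl in place of 4-nitrophenyl on a carbonyl carbon, and it brings an at least 10-fold lower number from compound 3 to compound 1 (1.03 log units; beyond the scatter). The cores of compound 3 and compound 2 differ by hydrogen in place of phenyl on a saturated chain carbon bound to an amide-type nitrogen; the step that the two limits leave unreadable from compound 2 to compound 3 cannot be sized due to the limit of > 100000 nM in this assay, at which 2 of the 3 values shown sit.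

Compound 4 `CNC(=O)CSc1nc2ccc(NC(C)=O)cc2s1`, not yet measured, arises from compound 2 by the same change, (methyl in place of 4-nitrophenyl on a carbonyl carbon), at the same place. Since compound 2 sits at a limit, the step of an at least 5.0-fold lower number from compound 2 to compound 4 (0.69 log units; beyond the scatter) is only an expectation, resting on the step from compound 3 to compound 1 an at least 10-fold lower number from compound 3 to compound 1 (1.03 log units; beyond the scatter). Compound 4 is therefore estimated at 20000 nM, with a range from 5000 nM to 100000 nM.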

Compound 4, half-maximal inhibitory concentration: > 100000 nM
Compound 4 gave a limit, no number (the forecaster's own chance of this, stated with the estimate: 35%); middle value at least 5.0-fold (0.69 log units) from the limit.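

In this assay compound 4 gives > 100000 nM as a limit of the assay and not a number, so methyl in place of 4-nitrophenyl on a carbonyl carbon yields no measurable value on this core. With the phenyl on the saturated chain carbon, the same change does give a number, and the step of an at least 10-fold higher number from compound 1 to compound 4 (1.03 log units; beyond the scatter) comes with hydrogen in place of that phenyl. This does not show that the change has no effect on the core of compound 2, since steps between two limits cannot be read: the limit of > 100000 nM in this assay, at which 3 of the 4 values shown sit.

Still open, going by these compounds, is whether the phenyl itself is needed for a measurable value. An amine or a longer chain at that place could test this.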